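Trimming the Chain End of Compound 3

This account rests on a few compounds, and the source may have more. Where it says the series, first, only, none or still open, it means among the compounds named here.

Four compounds share one core and differ in the group on an aromatic carbon. In an ADME assay on L1210/0 cells (Mus musculus) for cytotoxicity, with a stated time of 48 h (a higher number here means a weaker inhibitor, a lower number a stronger inhibitor), compound 1 `[N-]=[N+]=NCc1cn([C@H]2C[C@H](O)[C@@H](CO)O2)c(=O)[nH]c1=O`, which carries azidomethyl, gives 124000 nM. Compound 2 `COCC#Cc1cn([C@H]2C[C@H](O)[C@@H](CO)O2)c(=O)[nH]c1=O`, which carries 3-methoxyprop-1-yn-1-yl, reads > 200000 nM, and this is a limit of the assay, not a number. Compound 3 `CCCCCC#Cc1cn([C@H]2C[C@H](O)[C@@H](CO)O2)c(=O)[nH]c1=O`, which carries hept-1-yn-1-yl, reads > 200000 nM, which is again a limit. Compound 3 thus has no exact value and stands with compound 2 at the limit of > 200000 nM in this assay, at which 2 of the 3 values shown sit.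

Compound 4 `CCCCC#Cc1cn([C@H]2C[C@H](O)[C@@H](CO)O2)c(=O)[nH]c1=O` differs from compound 3 by hydrogen in place of methyl on a saturated chain carbon, four bonds along the chain from a triple-bonded carbon.

The nearest measured change to a chain is a step that the two limits leave unreadable from compound 2 to compound 3, so it offers no size to carry over. Replacing azidomethyl gave an at least 1.6-fold higher number from compound 1 to compound 2 (0.20 log units; that floor lies within the scatter) and an at least 1.6-fold higher number from compound 1 to compound 3 (0.20 log units; that floor lies within the scatter), so these steps show no shift beyond the scatter either. No step beyond the scatter, in either direction, is therefore expected in this assay for this small trim. The estimate means a number no higher from compound 3 to compound 4 (the limit leaves the size open), an expected step inside the scatter. Compound 4 is estimated at 200000 nM, with an expected range from 110000 nM to 360000 nM, and it may well be reported only as a limit.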

Compound 4, half-maximal inhibitory concentration: > 200000 nM
Compound 4: no number, only a limit; the forecaster's own chance of this, stated with the estimate: 75%; the middle value lies on the limit itself.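

Trimming hept-1-yn-1-yl to hex-1-yn-1-yl leaves compound 4 at a limit of the assay as well, so its steps from compound 2 and compound 3 cannot be read, and the size of this trim stays unknown. Going by these compounds alone, the only readable step is an at least 1.6-fold higher number from compound 1 to compound 4 (0.20 log units; that floor lies within the scatter), so replacing azidomethyl with hex-1-yn-1-yl shows no shift beyond the scatter, as with the other two groups built on a triple bond. What is new is that a third such group on this aromatic carbon ends at the same limit, which now holds most of the series: the limit of > 200000 nM in this assay, at which 3 of the 4 values shown sit.

The compounds shown therefore cannot tell whether the length of the chain on the triple bond matters at all in this assay, since only compound 1 has an exact number. From the compounds shown here alone, it remains open whether a bare ethynyl group or a chain carrying an amine would give an exact number here rather than another limit.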